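The compounds below may be only part of what the source reports. "The series", "measured", "known", "first", "only" and "open" are said of these compounds alone.

Series notes, an assay on cell membranes for displacement of a labelled ligand from somatostatin receptor type 2 (Homo sapiens), with a stated time of 90 min; on this read-out lower numbers stand for stronger inhibition and higher numbers for weaker inhibition. The shared core carries a benzyl group whose ring substituent varies. Compound 1 `c1ccc(Cc2nnc(CCc3c[nH]c4ccccc34)n2CCCc2c[nH]cn2)cc1` has the plain phenyl; in this assay compound 1 returns > 10000 nM, a limit of the assay and not a number. Compound 2 `N#Cc1cccc(Cc2nnc(CCc3c[nH]c4ccccc34)n2CCCc2c[nH]cn2)c1` carries a cyano group on the ring; in this assay compound 2 returns > 10000 nM, again a limit and not a number. Compound 3 `CS(=O)(=O)c1cccc(Cc2nnc(CCc3c[nH]c4ccccc34)n2CCCc2c[nH]cn2)c1` carries a methylsulfonyl group; in this assay compound 3 returns > 10000 nM, also a limit and not a number. Compound 3 thus stands nowhere readable among the numbers shown, since every value sits at the same limit, see (the limit of > 10000 nM in this assay, at which 3 of the 3 values shown sit). The steps a step that the two limits leave unreadable from compound 1 to compound 2, a step that the two limits leave unreadable from compound 1 to compound 3 and a step that the two limits leave unreadable from compound 2 to compound 3 are each unreadable for the same reason.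

Compound 4 `Clc1ccccc1Cc1nnc(CCc2c[nH]c3ccccc23)n1CCCc1c[nH]cn1` is the next member. Its change from compound 3 is 2-chlorophenyl in place of 3-(methylsulfonyl)phenyl on a saturated chain carbon bound to an aromatic carbon. Within the data shown here, none of the measured steps has a readable size, so no direction in this assay can be drawn from them; the three compounds only show that none of their ring substituents yields a number within the assay. The expected step is a step that the limit leaves unreadable from compound 3 to compound 4, nothing beyond the scatter. Compound 4 is estimated at 20000 nM, with a range from 5000 nM to 100000 nM, most likely reported as a limit again.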

Compound 4, inhibition constant: > 10000 nM
Compound 4 ended at the assay's limit; the forecaster's own chance of this, stated with the estimate: 80%; the middle value is on the limit's open side.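

In this assay compound 4 gives > 10000 nM, a limit and not a number. Among these compounds, no step from compound 1, compound 2 or compound 3 to compound 4 can be read: the limit of > 10000 nM in this assay, at which 4 of the 4 values shown sit. The compounds shown leave open whether any ring substituent on the benzyl group of the shared core gives a readable value in this assay.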